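Removing the Benzyl Group from a Cyclic Sulfonamide

The compounds below may be only part of what the source reports. "The series", "measured", "known", "first", "only" and "open" are said of these compounds alone.

For the measured compounds named here, the three compounds measured so far share a fused bicyclic core. Compound 1 `O=C1NS(=O)(=O)N(COCCO)c2ccccc21` carries a hydroxyethoxymethyl chain and an unsubstituted amide nitrogen; in a functional assay on CCRF-CEM cells (Homo sapiens) for cytotoxicity (on this read-out higher numbers stand for lower toxicity in this test and lower numbers for higher toxicity in this test), compound 1 gives 15 ug/mL. Compound 2 `CC(=O)OCCOCN1c2ccccc2C(=O)N(Cc2ccccc2)S1(=O)=O` bears an acetate ester on that chain and a benzyl group on the amide nitrogen, and in this assay compound 2 gives 103 ug/mL, the highest number of the three, though compound 3 `O=C(OCCOCN1c2ccccc2C(=O)N(Cc2ccccc2)S1(=O)=O)c1ccccc1`, the benzoate analogue, sits within the scatter of it with 100 ug/mL. Going by the values given here, the only single-change step available, a 1.0-fold lower number from compound 2 to compound 3 (0.01 log units; within the scatter), shows that swapping the ester group leaves the result essentially unchanged.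

Compound 4 `CC(=O)OCCOCN1c2ccccc2C(=O)NS1(=O)=O` differs from compound 2 in one place: hydrogen in place of benzyl on an amide-type nitrogen in a ring. Among the compounds with values here, no measured pair isolates this change, since compound 1 differs from compound 2 both at the nitrogen and at the chain end. Within the data shown here, the gap between compound 1 and compound 2 is therefore the only guide, and it cannot be split between the two differences.

For that reason compound 4 is expected to fall between the two, with an estimated 2.9-fold lower number from compound 2 to compound 4 (0.47 log units; beyond the scatter) toward lower numbers. The estimate for compound 4 is 35 ug/mL, with a range from 10 ug/mL to 110 ug/mL.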

Compound 4, half-maximal cytotoxic concentration: > 200 ug/mL
Compound 4 gave a limit, no number; the forecaster's own chance of this, stated with the estimate: 5%; middle value at least 5.7-fold (0.75 log units) from the limit.
By their numbers in this assay, from the lowest: compound 1; then compounds 3 and 2 (each within the scatter of the next). At a limit, above all of these: compound 4.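

In this assay, compound 4 reached a limit of the read-out and not a number: the limit of > 200 ug/mL in this assay, at which 1 of the 4 values shown sits.

Taking the benzyl group off the amide-type nitrogen gives an at least 1.9-fold higher number from compound 2 to compound 4 (0.28 log units; that floor lies within the scatter), so this position can carry plain hydrogen with no fall toward lower numbers, although that floor is too small to establish a real rise. The earlier compounds shown here could not show this, as none of them isolated the benzyl group from the chain end. The second step separates the chain end on its own: with hydrogen on the amide-type nitrogen on both sides, acetyl in place of hydrogen on the chain-end oxygen gives an at least 13-fold higher number from compound 1 to compound 4 (1.12 log units; beyond the scatter), a large change from one small difference in a single place.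

From the compounds shown here alone, how far the true value of compound 4 lies past its limit remains unknown, and so does the full size of both steps. Going by these compounds, it also remains open whether a methyl group or a longer carbon chain on the amide-type nitrogen would fit this picture, and whether an amine or a carboxylic acid at the end of the side chain would match the acetate or the free hydroxyl.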